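The source may hold more compounds than are shown below. What is called first, only, known or untested is meant among the compounds shown, and "the series" means these compounds.

Compound 1 `CCN(CC)Cc1ccc2nc(NC(=O)N/N=C/c3ccccn3)sc2c1` was tested in a functional assay on MCF7 cells (Homo sapiens) for antiproliferative activity, read by CCK-8 assay, with a stated time of 24 h; on this read-out higher numbers stand for weaker inhibition and lower numbers for stronger inhibition. In this assay compound 1 gives only the limit > 40000 nM, which is a limit of the assay and not a number. Compound 2 `CCN(CC)Cc1ccc2nc(NC(=O)N/N=C(\C)c3ccccn3)sc2c1` differs from compound 1 by a group of 9 heavy atoms (7 carbon, 2 nitrogen; one six-membered aromatic ring with 1 hetero atom) in place of a group of 8 heavy atoms (6 carbon, 2 nitrogen; one six-membered aromatic ring with 1 hetero atom), on an amide-type nitrogen. In this assay compound 2 also gives only the limit > 40000 nM. The step that the two limits leave unreadable from compound 1 to compound 2 cannot be sized because both values sit at the limit of > 40000 nM in this assay, at which 3 of the 3 values shown sit.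

Compound 3 `CC1CCN(Cc2ccc(NC(=O)N/N=C/c3ccccn3)cc2)CC1` has another core; the difference between the two cores is not broken down here. In this assay compound 3 likewise reaches only the limit > 40000 nM.

Compound 4 `C/C(=N\NC(=O)Nc1ccc(CN2CCC(C)CC2)cc1)c1ccccn1` has not been measured. It relates to compound 3 by a group of 9 heavy atoms (7 carbon, 2 nitrogen; one six-membered aromatic ring with 1 hetero atom) in place of a group of 8 heavy atoms (6 carbon, 2 nitrogen; one six-membered aromatic ring with 1 hetero atom), on an amide-type nitrogen, the same change that separates compound 1 from compound 2, made at the same place. For compound 4 the step expected is a number no higher from compound 3 to compound 4 (the limit leaves the size open), resting on the unreadable step that the two limits leave unreadable from compound 1 to compound 2 and on the fact that every measured value here sits at the limit of > 40000 nM in this assay, at which 3 of the 3 values shown sit. Compound 4 is therefore estimated at 40000 nM, with an expected range from 10000 nM to 150000 nM, and most likely the result will again be only a limit.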

Compound 4, half-maximal inhibitory concentration: > 40000 nM
Compound 4: a limit, no number; the forecaster's own chance of this, stated with the estimate: 80%; the middle value lies on the limit itself.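

No size can be read for the step from compound 3 to compound 4, nor for any other step here, because the values in this assay are limits and not numbers: the limit of > 40000 nM in this assay, at which 4 of the 4 values shown sit. The compounds shown leave open whether exchanging these groups on the amide-type nitrogen changes antiproliferative activity at all.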